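Imidazolylethyl sulfanyl chain in place of a carbamoylethyl chain

The source may hold more compounds than are shown below. What is called first, only, known or untested is meant among the compounds shown, and "the series" means these compounds.

The measured compounds and their numbers in a functional assay on HT cells (Homo sapiens) for antiproliferative activity, read by fluorescence, with a stated time of 72 h; on this read-out lower numbers stand for stronger inhibition of growth and higher numbers for weaker inhibition of growth:
compound 1, `CC(C)c1n[nH]c2c(NCc3ccc(-c4ccccn4)cc3)nc(SCCC(N)=O)nc12`: 120 nM
compound 2, `CC(O)CSc1nc(NCc2ccc(-c3ccccn3)cc2)c2[nH]nc(C(C)C)c2n1`: 62 nM
compound 3, `CC(C)c1n[nH]c2c(NCc3ccc(-c4ccccn4)cc3)nc(SCC(N)=O)nc12`: 192 nM

Compound 1 stands second highest of the three numbers; its nearest neighbour is compound 3, and the step of a 1.6-fold higher number from compound 1 to compound 3 (0.20 log units; within the scatter) stays within the scatter, as does the step of a 1.9-fold lower number from compound 1 to compound 2 (0.29 log units; within the scatter). Going by the values given here, only the step of a 3.1-fold higher number from compound 2 to compound 3 (0.49 log units; beyond the scatter) reaches beyond it, and it is modest.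

Compound 4, `CC(C)c1n[nH]c2c(NCc3ccc(-c4ccccn4)cc3)nc(SCCn3ccnc3)nc12`, keeps the shared core of compound 1 and changes only the chain end: 1H-imidazol-1-yl in place of carbamoyl on a saturated chain carbon, two bonds along the chain from a sulfur

Among the compounds with values here, the steps that bear on this change are those along the same sulfanyl chain, the step from compound 1 to compound 2 and the step from compound 1 to compound 3; both were small. Within the data shown here, the change to compound 4 is larger in what it swaps, an aromatic ring entering where an amide left, yet the account so far gives no step of size at this place. The number for compound 4 is therefore expected to stay close to that of compound 1, with the estimated step of no change at the digits printed from compound 1 to compound 4 (within the scatter) lying within the scatter in either direction. Compound 4 is estimated at 120 nM, with a range from 45 nM to 320 nM.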

Compound 4, concentration for 50% growth inhibition: 155 nM
The estimate for compound 4 lay 1.3-fold (0.11 log units) below the measured number, within the range that was stated.
By their numbers in this assay, from the lowest: compounds 2, 1, 4 and 3 (each within the scatter of the next, the first and the last beyond it).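

In this assay, 1H-imidazol-1-yl in place of carbamoyl on a saturated chain carbon, two bonds along the chain from a sulfur, gives a 1.3-fold higher number from compound 1 to compound 4 (0.11 log units; within the scatter), so at this place a five-membered aromatic ring with no hydrogen-bond donor is tolerated as well as the amide end. Going by these compounds alone, the shorter amide chain gives a similar reading, a 1.2-fold lower number from compound 3 to compound 4 (0.09 log units; within the scatter), while the hydroxyl-bearing chain remains separated, with a 2.5-fold higher number from compound 2 to compound 4 (0.40 log units; beyond the scatter), the only new step beyond the scatter, and a modest one. No supporting data accompany these numbers to account for them.

The compounds shown leave open how a basic amine or a carboxylic acid would fare at the chain end. They also leave open whether a longer chain carrying the 1H-imidazol-1-yl ring, or a phenyl ring in its place, would read the same.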